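The compounds below may be only part of what the source reports. "The series", "measured", "known", "first", "only" and "open" are said of these compounds alone.

Compound 1 `COc1cc(CN(CCCO)Cc2ccc(O)c(OC)c2)ccc1O` and compound 3 `COc1cc(CN(CCCO)Cc2cc(OC)c(O)c(OC)c2)cc(OC)c1O` carry the same groups on the amine nitrogen but differ in their cores; the difference between the two cores is not broken down here. In a functional assay, with a stated time of 30 min (on this read-out lower numbers stand for stronger inhibition and higher numbers for weaker inhibition), compound 1 gives 13700 nM, and compound 3 gives 12300 nM, the two values lying within the usual scatter of one another. Compound 2 `COc1cc(CN(Cc2ccccc2)Cc2ccc(O)c(OC)c2)ccc1O` is compound 1 with phenyl in place of 2-hydroxyethyl on a saturated chain carbon bound to an amine nitrogen, and in this assay compound 2 gives 29700 nM, so that a 2.2-fold higher number from compound 1 to compound 2 (0.34 log units; beyond the scatter). Compound 4 `COc1cc(CN(Cc2ccccc2)Cc2cc(OC)c(O)c(OC)c2)cc(OC)c1O` has not yet been measured; it stands to compound 3 as compound 2 stands to compound 1, carrying phenyl in place of 2-hydroxyethyl on a saturated chain carbon bound to an amine nitrogen on the other core. The earlier step of a 2.2-fold higher number from compound 1 to compound 2 (0.34 log units; beyond the scatter) is modest, and compound 3 sits with 12300 nM close to compound 1 in this assay, so a step of similar size is expected for compound 4, the estimated step being a 2.1-fold higher number from compound 3 to compound 4 (0.33 log units; beyond the scatter). Compound 4 is accordingly expected to give about 26000 nM in this assay, with a likely range from 12000 nM to 60000 nM.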

Compound 4, half-maximal inhibitory concentration: 15400 nM
Estimate against measurement, compound 4: 1.7-fold (0.23 log units) above; measured number inside the range.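

In this assay the change of 2-hydroxyethyl to phenyl on a saturated chain carbon bound to an amine nitrogen comes to a 1.3-fold higher number from compound 3 to compound 4 (0.10 log units; within the scatter) on the core of compound 3. Set beside the step on the core of compound 1, this step cannot be told apart from it: the same change on two cores in this assay, a 2.2-fold higher number (0.34 log units; beyond the scatter) from compound 1 to compound 2 and a 1.3-fold higher number (0.10 log units; within the scatter) from compound 3 to compound 4, 1.7-fold (0.24 log units) apart, within the scatter of two such steps. Among the compounds shown here, this shows that the two cores give no measurable disagreement about the change, but it does not show that the change carries over at a fixed size, for only the step on the core of compound 1 lies beyond the scatter, and a single pair on each core cannot settle the matter or explain it.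

The compounds shown leave open what other groups would do in place of 3-hydroxypropyl or benzyl on the amine nitrogen, such as a longer chain, a carboxylic acid or a second amine. They also leave open whether the change would give a similar step on any further core.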